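Nitro-for-hydrogen step on the shared core: working notes

This account rests on a few compounds, and the source may have more. Where it says the series, first, only, none or still open, it means among the compounds named here.

Measured so far in a functional assay on A549 cells (Homo sapiens) for antiproliferative activity, read by MTT assay, with a stated time of 72 h; on this read-out lower numbers stand for stronger inhibition and higher numbers for weaker inhibition:
compound 1 `COc1cc(-c2ncnn2-c2ccccc2)cc(OC)c1OC` gives > 10000 nM
compound 2 `COc1cc(-c2ncnn2-c2ccc(Cl)c(Cl)c2)cc(OC)c1OC` gives > 10000 nM
compound 3 `COc1cc(-c2ncnn2-c2cccc([N+](=O)[O-])c2)cc(OC)c1OC` gives > 10000 nM

The value of compound 1 in this assay is a limit of the assay and not a number. The value of compound 2 is likewise only a limit. The value of compound 3 is also a limit. All three values shown sit at the limit of > 10000 nM in this assay, at which 3 of the 3 values shown sit, so compound 1 has no readable place on a scale of potency; it merely shares the limit with the other two.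

Compound 4 `COc1cc(-c2ncnn2-c2ccc([N+](=O)[O-])cc2)cc(OC)c1OC` is yet to be measured. It differs from compound 1 by nitro in place of hydrogen on an aromatic carbon. Two measured steps start from compound 1 and bear on this change: a step that the two limits leave unreadable from compound 1 to compound 2 and a step that the two limits leave unreadable from compound 1 to compound 3. Neither has a readable size, as both ends rest on the same limit. Compound 3 carries a nitro group on the same six-membered ring and stays at the limit, which is the closest guide available.

No step beyond the scatter can be read from these data, and none is expected for compound 4. Compound 4 is expected to give about 20000 nM in this assay, with a range of 8000 nM to 60000 nM. The step that the limit leaves unreadable from compound 1 to compound 4 is estimated as essentially none, and the assay is expected most likely to report only a limit again.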

Compound 4, half-maximal inhibitory concentration: > 10000 nM
Compound 4 gave a limit, no number; the forecaster's own chance of this, stated with the estimate: 85%; the middle value is on the limit's open side.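

No new step can be read between compound 1 and compound 4, as both rest on a limit in this assay and not on a number: the limit of > 10000 nM in this assay, at which 4 of the 4 values shown sit.

The compounds shown leave open how large the step of nitro in place of hydrogen really is, and whether any change on the shared core gives a readable value in this assay.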